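This account rests on a few compounds, and the source may have more. Where it says the series, first, only, none or still open, it means among the compounds named here.

Values so far in a functional assay on OVCAR-3 cells (Homo sapiens) for cytotoxicity, read by sulforhodamine B assay (a higher number here means a weaker inhibitor of growth, a lower number a stronger inhibitor of growth), are these:
compound 1 `CC1=CC[C@@H]([C@@](C)(O)CCCC(C)(C)NC=S)CC1` gives 12100 nM as its result
compound 2 `COc1ccc(/C=N\NC(=S)NC(C)(C)CCC[C@](C)(O)[C@@H]2CC=C(C)CC2)cc1` gives 6500 nM as its result

Compound 2 at 6500 nM and compound 1 at 12100 nM lie within the usual scatter of each other, so neither can be ranked above the other. Compound 3 `CC1=CC[C@@H]([C@@](C)(O)CCCC(C)(C)NC(=S)N/N=C\c2ccc([N+](=O)[O-])cc2)CC1` is compound 2 with a single change, (nitro in place of methoxy on an aromatic carbon), which puts nitro in place of methoxy on an aromatic carbon, para to a large group. Among the measured compounds shown here, no measured pair here shows what such a change does in this assay, so no step beyond the scatter is expected in either direction. The estimate therefore starts from compound 2 at 6500 nM and stays close to it. The expected change is a 1.2-fold lower number from compound 2 to compound 3 (0.07 log units; within the scatter) and is estimated to remain within the scatter. Compound 3 is estimated at 5500 nM in this assay, with 2000 nM to 15000 nM as the expected range.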

Compound 3, concentration for 50% growth inhibition: 13400 nM
For compound 3 the middle estimate is 2.4-fold (0.39 log units) below the measured one; low and high end bracket the measured number.
By their numbers in this assay, from the lowest: compounds 2, 1 and 3 (each within the scatter of the next, the first and the last beyond it).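

In this assay, among the compounds shown here, nitro in place of methoxy on this aromatic carbon, para to a large group, gives a 2.1-fold higher number from compound 2 to compound 3 (0.31 log units; beyond the scatter) and is the first step that can be read beyond the scatter. The position is therefore not indifferent to the group it carries, although the step is modest and rests on this single pair. Of these two groups, methoxy goes with the stronger inhibition of growth, but no information available here accounts for the difference.

On these data alone, what remains open is how other groups on the same carbon would compare, such as an amine, a carboxylic acid or a plain hydrogen. As far as these compounds go, it is also open whether moving the methoxy or the nitro elsewhere on the aromatic ring would give a step of similar size.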